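The compounds below may be only part of what the source reports. "The series", "measured", "known", "first", "only" and "open" are said of these compounds alone.

Measured compounds and values:
- compound 1 `Cc1nc(S(C)(=O)=O)ccc1Oc1ncnc(OC2CCN(C(=O)OC3CCC3)CC2)c1F` gives 13.6 nM in a functional assay on isolated protein for inhibition of Glucose-dependent insulinotropic receptor (Homo sapiens), read by HTRF and cAMP accumulation; on this read-out lower numbers stand for an effect already at smaller amounts and higher numbers for an effect only at larger amounts of compound
- compound 2 `Cc1nc(S(C)(=O)=O)ccc1Oc1ncnc(OC2CCN(C(=O)O[C@@H](C)CF)CC2)c1F` gives 186 nM in this assay
- compound 3 `Cc1nc(S(C)(=O)=O)ccc1Oc1ncnc(OC2CCN(C(=O)SC3CCC3)CC2)c1F` gives 8.51 nM in this assay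

Compound 3 has the lowest number of the three. Its nearest neighbour is compound 1, and that pair lies within the scatter: a 1.6-fold lower number from compound 1 to compound 3 (0.20 log units; within the scatter). Its furthest neighbour is compound 2: a 22-fold lower number from compound 2 to compound 3 (1.34 log units; beyond the scatter).

The unmeasured compound 4 `Cc1nc(S(C)(=O)=O)ccc1Oc1ncnc(OC2CCN(C(=O)c3noc(C(C)(C)F)n3)CC2)c1F` keeps the shared core and changes the group on the carbonyl carbon: a group of 9 heavy atoms (5 carbon, 2 nitrogen, 1 oxygen, 1 fluorine; one five-membered aromatic ring with 3 hetero atoms) in place of a group of 5 heavy atoms (4 carbon, 1 sulfur; one four-membered non-aromatic ring of carbon only), on a carbonyl carbon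

For the measured compounds named here, two measured steps touch this carbonyl position. The step from compound 1 to compound 3 shows that swapping cyclobutyloxy for cyclobutylsulfanyl changes little: a 1.6-fold lower number from compound 1 to compound 3 (0.20 log units; within the scatter). The step from compound 1 to compound 2 shows that replacing the cyclobutyl ring with an open fluorinated chain costs a great deal: a 14-fold higher number from compound 1 to compound 2 (1.14 log units; beyond the scatter). Neither step involves an aromatic ring attached directly to the carbonyl, so the change to compound 4 is largely untested here; what is known is that the carbonyl substituent can swing the result widely.

Compound 4 is therefore expected to land somewhat higher than compound 3, with a wide range, an estimated step of a 2.4-fold higher number from compound 3 to compound 4 (0.37 log units; beyond the scatter). The estimate for compound 4 in this assay is 20 nM, expected to fall between 4 nM and 100 nM.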

Compound 4, half-maximal effective concentration: 14 nM
Beside the measured number, compound 4's estimate is 1.4-fold (0.15 log units) above it; low and high end bracket the measured number.
By their numbers in this assay, from the lowest: compounds 3, 1 and 4 (each within the scatter of the next); then compound 2.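

In this assay a five-membered aromatic ring with 3 hetero atoms can stand on the carbonyl carbon in place of either cyclobutyl-containing group without a change beyond the scatter (a 1.6-fold higher number from compound 3 to compound 4 (0.22 log units; within the scatter)) and (a 1.0-fold higher number from compound 1 to compound 4 (0.01 log units; within the scatter)). This position therefore accepts a group of 9 heavy atoms, with an aromatic ring and no oxygen or sulfur link to the carbonyl carbon, so the cyclobutyloxy and cyclobutylsulfanyl groups are not the only ones that give a low number here. Compound 2 stays apart from this group (a 13-fold lower number from compound 2 to compound 4 (1.12 log units; beyond the scatter)), and since compound 4 carries a fluorine as well, a fluorine in the group does not by itself go with a high number among these compounds.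

Still open, from the compounds shown here alone, is whether the aromatic ring or the fluorine-bearing group on it matters more, which the same ring carrying a plain methyl group, or a phenyl ring on the carbonyl carbon, could help to separate. Nothing measured here explains why such different groups give such similar numbers.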